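The compounds below may be only part of what the source reports. "The series", "measured", "known", "first", "only" and "open" are said of these compounds alone.

The study concerns four compounds built on one shared core, examined in a functional assay on ACHN cells (Homo sapiens) for cytotoxicity, read by MTT assay, with a stated time of 48 h; on this read-out higher numbers stand for weaker inhibition and lower numbers for stronger inhibition. Compound 1 `COc1ccc(-c2cc(C(=O)Nc3nc4ccc(F)cc4s3)nc3cc(-c4ccccc4)nn23)cc1` gives 39300 nM in this assay. Compound 2 `COc1ccc(-c2cc(C(=O)Nc3nc4ccc(F)cc4s3)nc3cc(-c4ccccc4)nn23)cc1OC` carries one further group on its outer ring and gives 8120 nM in this assay. Compound 3 `COc1ccc(-c2cc(C(=O)Nc3nc4ccccc4s3)nc3cc(-c4ccccc4)nn23)cc1` differs from compound 1 at the fused ring; in this assay compound 3 gives 1690 nM, holds the lowest number of the three measured compounds, and its steps to both of the others are beyond the scatter. Compound 4 `COc1ccc(-c2cc(C(=O)Nc3nc4ccccc4s3)nc3cc(-c4ccccc4)nn23)cc1OC` has not yet been measured.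

Two changes connect these compounds. The first, (methoxy in place of hydrogen on an aromatic carbon), made the step of a 4.8-fold lower number from compound 1 to compound 2 (0.68 log units; beyond the scatter). The second, (hydrogen in place of fluoro on an aromatic carbon), made the step of a 23-fold lower number from compound 1 to compound 3 (1.37 log units; beyond the scatter), and this is the whole of how the cores of compound 1 and compound 3 differ. The change from compound 3 to compound 4, (methoxy in place of hydrogen on an aromatic carbon), is the same change that separates compound 1 and compound 2, with the same surroundings at its place; it occurs twice among the compounds shown, once measured and once not.

The step from compound 3 to compound 4 is expected to be a 3.4-fold lower number from compound 3 to compound 4 (0.53 log units; beyond the scatter). This expectation rests on the earlier step of a 4.8-fold lower number from compound 1 to compound 2 (0.68 log units; beyond the scatter) and on the starting value of compound 3, 1690 nM, allowing that a second occurrence of a change need not repeat the first in full. Compound 4 is therefore estimated at 500 nM, within a range from 150 nM to 1700 nM.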

Compound 4, half-maximal inhibitory concentration: 7940 nM
Beside the measured number, compound 4's estimate is 16-fold (1.20 log units) below it; the whole stated range lies below it.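

In this assay, the methoxy change did not carry from one core to the other: a 4.7-fold higher number from compound 3 to compound 4 (0.67 log units; beyond the scatter), against the earlier 4.8-fold lower number from compound 1 to compound 2 (0.68 log units; beyond the scatter), so the difference from 4-methoxyphenyl to 3,4-dimethoxyphenyl has no single direction or size in this series: the same change on two cores in this assay, a 4.8-fold lower number (0.68 log units; beyond the scatter) from compound 1 to compound 2 and a 4.7-fold higher number (0.67 log units; beyond the scatter) from compound 3 to compound 4, 23-fold (1.36 log units) apart, beyond the scatter of two such steps

The fluoro-to-hydrogen change likewise depends on its surroundings, with a 23-fold lower number from compound 1 to compound 3 (1.37 log units; beyond the scatter) set against a 1.0-fold lower number from compound 2 to compound 4 (0.01 log units; within the scatter): the same change on two cores in this assay, a 23-fold lower number (1.37 log units; beyond the scatter) from compound 1 to compound 3 and a 1.0-fold lower number (0.01 log units; within the scatter) from compound 2 to compound 4, 23-fold (1.36 log units) apart, beyond the scatter of two such steps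

Together these steps show that, across these four compounds, the two changes do not act independently, so the size of either one on one core does not give its size on the other; they do not show why this is so, and with only one pair for each comparison they offer no rule for any other core.

The compounds shown leave open whether the reversal belongs to the methoxy group alone or would also appear with a hydroxy group, an amine or a longer alkoxy chain on the outer ring. They also leave open whether a chloro group or a methyl group in place of the fluoro would show the same dependence on the outer ring.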